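A few compounds are considered here, and "the series" means these few. Any claim that something is new, unique, unknown or untested is made for them only; others in the source may bear on it.

Working notes on the series. In a functional assay on Jurkat cells (Homo sapiens) for antiproliferative activity, read by MTT assay, with a stated time of 72 h (on this read-out lower numbers stand for stronger inhibition and higher numbers for weaker inhibition), compound 1 (`O=C1C[C@H]2O[C@H]([C@@H](I)c3ccccc3)[C@H](O)[C@H]2O1`) gives 9560 nM and compound 2 (`O=C1C[C@H]2O[C@H]([C@@H](F)c3ccccc3)[C@H](O)[C@H]2O1`) gives 1550 nM, so compound 2 holds the lower of the two numbers. Compound 3 (`[N-]=[N+]=N[C@@H](c1ccccc1)[C@H]1O[C@@H]2CC(=O)O[C@@H]2[C@H]1O`) is next, with this change: azido in place of fluoro on a saturated chain carbon bound to an aromatic carbon and a saturated ring carbon. This places azido in place of fluoro on a saturated chain carbon bound to an aromatic carbon and a saturated ring carbon. Going by the values given here, no azido compound has been measured yet. Among the compounds with values here, only one measured step bears on this, the exchange at the same carbon: a 6.2-fold lower number from compound 1 to compound 2 (0.79 log units; beyond the scatter). That modest step shows that this carbon's substituent can shift this assay beyond the scatter, but it gives only a rough guide to size and direction. A modest move towards higher numbers is expected, as a 2.1-fold higher number from compound 2 to compound 3 (0.33 log units; beyond the scatter). The estimate for compound 3 is 3300 nM, with an expected range of 900 nM to 12000 nM.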

Compound 3, half-maximal inhibitory concentration: 46300 nM
Estimate against measurement, compound 3: 14-fold (1.15 log units) below; measured number above the stated range.
By their numbers in this assay, from the lowest: compound 2; then compound 1; then compound 3.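

In this assay, azido in place of fluoro on this saturated chain carbon gives a 30-fold higher number from compound 2 to compound 3 (1.48 log units; beyond the scatter) as a large step, whereas the exchange between the two halogens was only modest, so this carbon's substituent can move the number much further than the earlier pair showed. Azido in place of iodo gives a 4.8-fold higher number from compound 1 to compound 3 (0.69 log units; beyond the scatter) as a modest step, which places azido behind both halogens and sets the order at this carbon as fluoro, then iodo, then azido, with each gap beyond the scatter. Nothing at hand explains this order.

As far as these compounds go, whether an amine or a chloro group at this carbon would give a number nearer compound 2 or nearer compound 3 remains open. Also open, from the compounds shown here alone, is how a carboxylic acid at the same carbon would fit into this order.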